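A few compounds are considered here, and "the series" means these few. Any claim that something is new, unique, unknown or untested is made for them only; others in the source may bear on it.

Measured compounds in a functional assay on MCF7 cells (Homo sapiens) for antiproliferative activity; a higher number here means a weaker inhibitor, a lower number a stronger inhibitor:

- compound 1, `C#CCCCn1c(Cc2cc(OC)c(OC)c(OC)c2)nc2c(N)ncnc21`, gives 24000 nM
- compound 2, `CCC(C)Cn1c(Cc2cc(OC)c(OC)c(OC)c2)nc2c(N)ncnc21`, gives 61700 nM
- compound 3, `COc1cc(Cc2nc3c(N)ncnc3n2CC2CCC2)cc(OC)c1OC`, gives 45700 nM

All three share the same core and differ only in the group on a saturated chain carbon bound to an aromatic nitrogen. Compound 3 stands second highest of the three numbers. Its nearest neighbour on the numbers is compound 2, with the step of a 1.4-fold lower number from compound 2 to compound 3 (0.13 log units; within the scatter); the step of a 1.9-fold higher number from compound 1 to compound 3 (0.28 log units; within the scatter) is also within the scatter. Within the data shown here, the only step beyond the scatter in this set is a 2.6-fold higher number from compound 1 to compound 2 (0.41 log units; beyond the scatter), and even that is modest.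

Compound 4, `COc1cc(Cc2nc3c(N)ncnc3n2CC2(C)CC2)cc(OC)c1OC`, is not yet measured. It differs from compound 3 in one place: 1-methylcyclopropyl in place of cyclobutyl on a saturated chain carbon bound to an aromatic nitrogen. The two compounds have the same atoms, joined differently.

All three measured steps bear on this change, since each swaps one small carbon group for another at the same chain carbon, and none of them moved the number by much. The expected step in this assay is therefore small, with no clear direction, most likely within the scatter: a 1.1-fold higher number from compound 3 to compound 4 (0.04 log units; within the scatter). For compound 4 the estimate is 50000 nM, with a range from 20000 nM to 120000 nM.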

Compound 4, half-maximal inhibitory concentration: 112000 nM
Compound 4: the middle estimate sits 2.2-fold (0.35 log units) below what was measured; measured number inside the range.
By their numbers in this assay, from the lowest: compounds 1, 3, 2 and 4 (each within the scatter of the next, the first and the last beyond it).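

In this assay, rearranging the same four carbons from cyclobutyl to 1-methylcyclopropyl gives a 2.5-fold higher number from compound 3 to compound 4 (0.39 log units; beyond the scatter) as its step, so at this position a change of ring alone, with no atom gained or lost, can carry the number beyond the scatter, though only modestly. The new group does not separate from sec-butyl, with a 1.8-fold higher number from compound 2 to compound 4 (0.26 log units; within the scatter) as its step, but it does separate from but-3-yn-1-yl, with a 4.7-fold higher number from compound 1 to compound 4 (0.67 log units; beyond the scatter) as the largest step in the set, so the four compounds no longer all sit within the scatter of one another. No measurement shown here accounts for these differences, so the reason for them remains unknown.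

A plain butyl chain would help show whether the gap between compound 1 and compound 4 goes with the alkyne end of but-3-yn-1-yl or with the open chain itself. The compounds shown also leave open what an amine, a carboxylic acid or a much longer chain on this saturated chain carbon would do to the number.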